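The source may hold more compounds than are shown below. What is called first, only, known or untested is meant among the compounds shown, and "the series" means these compounds.

Measured compounds:
- compound 1 `CCCCc1c(CC)c(OC)c2ccccc2c1OC(C)=O` gives 990 nM
- compound 2 `CCc1c(CC)c(OC(C)=O)c2ccccc2c1OC` gives 400 nM
- compound 3 `CCc1c(CC)c(OC)c2c(OC)cccc2c1OC(C)=O` gives 890 nM

Among the compounds with values here, in a functional assay for inhibition, with Rattus norvegicus as the target (on this read-out lower numbers stand for stronger inhibition and higher numbers for weaker inhibition), compound 2 gives 400 nM, the lowest of the three numbers so far. Compound 4 `CCc1c(CC)c(OC(C)=O)c2cc(OC)ccc2c1OC` departs from it by a single change, (methoxy in place of hydrogen on an aromatic carbon), namely methoxy in place of hydrogen on an aromatic carbon.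

Two measured steps are available, and they do not bear on this change equally. The step of a 2.5-fold lower number from compound 1 to compound 2 (0.39 log units; beyond the scatter) is a change on a saturated chain, hydrogen in place of ethyl, so it says little here. The closer guide is a 2.2-fold higher number from compound 2 to compound 3 (0.35 log units; beyond the scatter), which is the same kind of replacement, methoxy in place of hydrogen, but on a different aromatic carbon. Within the data shown here, no measurement yet shows what methoxy does at the carbon it occupies in compound 4, and one step is thin support. A modest move toward a higher number in this assay is therefore expected, of about the size seen for the one measured methoxy replacement, although a step within the scatter would not be surprising.

For compound 4 the expected step is a 1.8-fold higher number from compound 2 to compound 4 (0.24 log units; within the scatter). Compound 4 is estimated at 700 nM, with an expected range from 300 nM to 1600 nM.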

Compound 4, half-maximal inhibitory concentration: 690 nM
Compound 4: middle estimate off by 1.0-fold (0.01 log units), on the high side; the measured number falls inside the stated range.
By their numbers in this assay, from the lowest: compounds 2, 4, 3 and 1 (each within the scatter of the next, the first and the last beyond it).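

With methoxy in place of hydrogen on an aromatic carbon, meta to a fused ring and para to a fused ring, a 1.7-fold higher number from compound 2 to compound 4 (0.24 log units; within the scatter) in this assay leaves compound 4 not separable from compound 2, which shows that this position accepts methoxy without a step beyond the scatter. Within the data shown here, the same kind of replacement at a different aromatic carbon gave a 2.2-fold higher number from compound 2 to compound 3 (0.35 log units; beyond the scatter), so across the two measured methoxy replacements only the one in compound 3 moves the number beyond the scatter, and the difference between these two steps is not itself established as real. No measured information explains the result at this position.

The compounds shown leave open how an amine, a carboxylic acid or a chlorine atom on this same aromatic carbon would read in this assay, as methoxy is the only group other than hydrogen seen there. They also leave open whether an ethoxy group, with its longer chain, would stay as close to compound 2 as the methoxy group of compound 4 does.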